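The compounds below may be only part of what the source reports. "The series", "measured", "known", "first", "only" and "open" are said of these compounds alone.

Working notes on the series, read in an ADME assay for permeability, using PAMPA, at pH 4; on this read-out higher numbers stand for higher permeability and lower numbers for lower permeability. Compound 1 (`Cc1[nH]c2ccccc2c(=O)c1Cc1ccccc1`) gives 110 10^-6 cm/s and compound 2 (`COc1cc2[nH]c(C)c(C3CCCCC3)c(=O)c2cc1Cl`) gives 1240 10^-6 cm/s, so compound 2 holds the higher of the two numbers, by a gap beyond the scatter. These two compounds differ in more than one place, and their gap cannot be assigned to any single change. Compound 3 (`COc1cc2[nH]c(C)c(Br)c(=O)c2cc1Cl`) carries bromo in place of cyclohexyl on an aromatic carbon of compound 2: bromo in place of cyclohexyl on an aromatic carbon. Among the compounds with values here, no measured pair isolates this change, so the expectation is loose. A moderate fall in this assay is expected, probably somewhat beyond the scatter, with a result within the scatter still possible. The expected change is a 3.5-fold lower number from compound 2 to compound 3 (0.55 log units; beyond the scatter). For compound 3 the estimated value is 350 10^-6 cm/s, with an expected range of 100 10^-6 cm/s to 1000 10^-6 cm/s.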

Compound 3, apparent permeability: 125 10^-6 cm/s
Compound 3: the middle estimate sits 2.8-fold (0.45 log units) above what was measured; measured number inside the range.
By their numbers in this assay, from the lowest: compounds 1 and 3 (each within the scatter of the next); then compound 2.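

Setting bromo in place of cyclohexyl on this aromatic carbon, ortho to a methyl group and two atoms from the ring nitrogen, gives the only isolated reading of this position in this assay: a 9.9-fold lower number from compound 2 to compound 3 (1.00 log units; beyond the scatter). With the rest of the structure unchanged, the group at this carbon alone moves the number beyond the scatter, so the read-out is not indifferent to what sits here. No measurement bearing on the reason for the step is available, and it stands as an observation on this one pair.

This single pair cannot separate the loss of the non-aromatic ring from the entry of bromine. As far as these compounds go, how a longer alkyl chain, an amine or a carboxylic acid at this carbon would read in this assay remains open, as does whether the step carries over to other substitution on the core.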